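Swapping the amide aryl group for a dimethylpyrimidine

This account rests on a few compounds, and the source may have more. Where it says the series, first, only, none or still open, it means among the compounds named here.

Measured compounds:
compound 1 `Cc1cc(C)cc(NC(=O)COc2cc(C)nc3ccc(OCc4ccccc4)cc23)c1` — 7.03
compound 2 `COc1ccc2nc(C(F)(F)F)cc(OCC(=O)Nc3cc(C)cc(C)c3)c2c1` — 7.02
compound 3 `COc1ccc2nc(C)cc(OCC(=O)Nc3c(C)cccc3C)c2c1` — 4.55

Of the compounds shown here, three built on a shared core have been measured in a physicochemical assay for lipophilicity, read by HPLC, in phosphate buffer, measured as chromatographic lipophilicity, at pH 7.4; on this read-out higher numbers stand for higher lipophilicity and lower numbers for lower lipophilicity. Compound 1 gives 7.03, compound 2 gives 7.02, and compound 3 gives 4.55. Compound 3 stands lowest of the three; its gap to compound 2 and its gap to compound 1 both lie beyond the scatter, while compound 1 and compound 2 sit within the scatter of each other.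

The next compound, compound 4 `COc1ccc2nc(C)cc(OCC(=O)Nc3cc(C)nc(C)n3)c2c1`, has not yet been measured. It differs from compound 3 in a single place: 2,6-dimethylpyrimidin-4-yl in place of 2,6-dimethylphenyl on an amide-type nitrogen. Going by the values given here, no measured pair shows this exact change, so the step has to be anticipated from the change itself. Two hetero atoms entering an aromatic ring that carried none, with two hydrogen-bond acceptors in place of none, is expected to lower the read-out in this assay by a step clearly beyond the scatter. The expected step from compound 3 is a number 1.25 log units lower from compound 3 to compound 4 (beyond the scatter). Compound 4 is therefore estimated at 3.3, with a range from 2.6 to 4.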

Compound 4, distribution coefficient: 3.24
Beside the measured number, compound 4's estimate is 0.06 log units above it; measured number inside the range.
By their numbers in this assay, from the lowest: compound 4; then compound 3; then compounds 2 and 1 (each within the scatter of the next).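

Going by these compounds alone, this is the first step that isolates a single place: on an amide-type nitrogen, with the rest of compound 3 unchanged, 2,6-dimethylpyrimidin-4-yl in place of 2,6-dimethylphenyl gives a number 1.31 log units lower from compound 3 to compound 4 (beyond the scatter) in this assay. The earlier compounds shown here differ from one another in more than one place and so gave no reading for this position, whereas this pair shows that the read-out responds strongly to a change in the ring on the amide nitrogen, even with the heavy-atom count unchanged, no hydrogen-bond donor added and no net charge on either group. Nothing measured here accounts for the size of the step.

The compounds shown leave open how much of the step would remain with a pyridine ring, which would show whether both ring nitrogens are needed for a drop of this size, and how the read-out would move with an amine or a carboxylic acid on the ring. They also leave open whether the same exchange would give a comparable step on the benzyloxy-bearing core of compound 1 or the trifluoromethyl-bearing core of compound 2.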